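A Thiourea Swap With No Measured Starting Point

The source may hold more compounds than are shown below. What is called first, only, known or untested is meant among the compounds shown, and "the series" means these compounds.

Compound 1 `COc1ccc(NC(=S)NC2CC(C)(C)Oc3ccc(Br)cc32)cc1`: "not determined" (no result reported)
Compound 2 `CC1(C)CC(NC(=S)Nc2ccc(C#N)cc2)c2cc(Cl)ccc2O1`: 7000 nM

In a functional assay on B16-F10 cells (Mus musculus) for inhibition, read by MTT assay, with a stated time of 72 h (a lower number here means a stronger inhibitor, a higher number a weaker inhibitor), compound 1 has the entry "not determined" (no result reported), so it offers no number to start from and cannot be placed above or below any other compound. The only figure available in this assay is that of compound 2, at 7000 nM.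

The step of interest leads from compound 1 to compound 3 `CC1(C)CC(NC(=S)Nc2ccccc2Cl)c2cc(Br)ccc2O1`. Here (2-chlorophenyl in place of 4-methoxyphenyl on an amide-type nitrogen), with 2-chlorophenyl in place of 4-methoxyphenyl on an amide-type nitrogen, and the rest of the core of compound 1 is kept.

For the measured compounds named here, no measured step between any two compounds is available to show how much such a change matters in this assay. Going by the values given here, with nothing to set a direction, no step beyond the usual scatter can be expected, and the expectation leans on the single value of compound 2 at 7000 nM, widened for the uncertainty. Compound 3 is estimated at 10000 nM, with an expected range from 3000 nM to 35000 nM.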

Compound 3, half-maximal inhibitory concentration: 17000 nM
Estimate against measurement, compound 3: 1.7-fold (0.23 log units) below; the measured number falls inside the stated range.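

In this assay compound 1 gives "not determined" (no result reported) and compound 3 gives 17000 nM and the pair therefore yields no readable step. The compounds shown leave open how 2-chlorophenyl in place of 4-methoxyphenyl on an amide-type nitrogen bears on inhibition. No supporting evidence bears on this result.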